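A Methyl Next to the Pyridine Nitrogen

The source may report more compounds than this note shows. Statements on the series, on what has been measured and on what is new or still open speak of the compounds shown alone.

compound 1 `COc1cccc(Cn2cnc3sc(-c4ccncc4)cc3c2=O)c1` — 45 nM
compound 2 `COc1cccc(Cn2cnc3sc(-c4ccnc(Cl)c4)cc3c2=O)c1` — > 10000 nM

In an assay on isolated protein for inhibition of Rho-associated protein kinase 1 (Homo sapiens), read by radiometric assay and 33P incorporation, with a stated time of 40 min, in the presence of a further agent that is not named here (on this read-out higher numbers stand for weaker inhibition and lower numbers for stronger inhibition), compound 1 gives 45 nM, the only number shown. Compound 2 reaches only a limit of the assay, and for compound 2 that limit is > 10000 nM, as the limit of > 10000 nM in this assay, at which 1 of the 2 values shown sits, records. Compound 3 `COc1cccc(Cn2cnc3sc(-c4ccnc(C)c4)cc3c2=O)c1` differs from compound 1 by methyl in place of hydrogen on an aromatic carbon. Among the measured compounds shown here, the single measured step at this place, an at least 220-fold higher number from compound 1 to compound 2 (2.34 log units; beyond the scatter), was large, and the methyl of compound 3 enters where the chloro of compound 2 did. Compound 3 is therefore expected to show a weakening step, a 22-fold higher number from compound 1 to compound 3 (1.35 log units; beyond the scatter), beyond the scatter. Compound 3 is estimated at 1000 nM, with a range from 150 nM to 10000 nM.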

Compound 3, half-maximal inhibitory concentration: 2520 nM
Compound 3: the middle estimate sits 2.5-fold (0.40 log units) below what was measured, and the stated range covers the measured number.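

A second group at this place, methyl, also weakens inhibition strongly, with a 56-fold higher number from compound 1 to compound 3 (1.75 log units; beyond the scatter), so the loss next to the ring nitrogen is not particular to chloro. Methyl in place of chloro nonetheless leaves measurable inhibition, with an at least 3.9-fold lower number from compound 2 to compound 3 (0.59 log units; beyond the scatter). That step has no fixed size because one end of it is a limit of the assay and not a number: the limit of > 10000 nM in this assay, at which 1 of the 3 values shown sits.

Going by these compounds, what a fluoro or an amino group would do at this place remains open, and so does whether any group here can keep the potency of compound 1.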